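Amide series: cytotoxicity limits on Vero cells

The source may hold more compounds than are shown below. What is called first, only, known or untested is meant among the compounds shown, and "the series" means these compounds.

Three members of the series have been measured in an ADME assay on Vero cells (Chlorocebus sabaeus) for cytotoxicity, read by resazurin assay, with a stated time of 3 days; a higher number here means a weaker inhibitor, a lower number a stronger inhibitor: compound 1 `CCN(CC)c1cc2[nH]c(C3CCCCC3)nc2cc1NC(=O)c1cnccn1`, compound 2 `CN(C)c1cc2[nH]c(C3CCCCC3)nc2cc1NC(=O)c1ccc(Br)cc1` and compound 3 `O=C(Nc1cc2nc(C3CCCCC3)[nH]c2cc1N1CCCC1)c1ccc(Br)cc1`. Compound 1 gives > 100 ug/mL, which is a limit of the assay and not a number. Compound 2 likewise gives only a limit, > 100 ug/mL. Compound 3 also stops at a limit, > 100 ug/mL. Among the compounds with values here, compound 2 therefore stands where every value so far stands, at the limit, with no readable number. Within the data shown here, the single step between measured compounds, a step that the two limits leave unreadable from compound 2 to compound 3, has no readable size because of the limit of > 100 ug/mL in this assay, at which 3 of the 3 values shown sit.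

Compound 4 `CN(C)c1cc2[nH]c(C3CCCCC3)nc2cc1NC(=O)c1cccc(Br)c1` is not yet measured. It differs from compound 2 by 3-bromophenyl in place of 4-bromophenyl on a carbonyl carbon. Among the measured compounds shown here, no measured step involves a change of this kind, and the one step available gives no size at all, so nothing in the data points to a shift in either direction. Since compound 2 sits at the limit, > 100 ug/mL, compound 4 is expected to sit there too. The expected step that the limit leaves unreadable from compound 2 to compound 4 is none beyond the scatter. For compound 4 the estimate is 150 ug/mL, with a range from 70 ug/mL to 400 ug/mL.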

Compound 4, half-maximal inhibitory concentration: > 100 ug/mL
Compound 4 was reported as a limit (the forecaster's own chance of this, stated with the estimate: 85%); the middle value is on the limit's open side.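

No step can be read from compound 2 to compound 4, because both results are limits and not numbers: (the limit of > 100 ug/mL in this assay, at which 4 of the 4 values shown sit).

The compounds shown leave open whether 3-bromophenyl in place of 4-bromophenyl, or any other change here, shifts cytotoxicity in this assay at all.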